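Hydroxyphenyl positional change on a pyridine-type core

The compounds below may be only part of what the source reports. "The series", "measured", "known", "first", "only" and "open" are said of these compounds alone.

Compound 1 `Oc1cccc(-c2cc(-c3ccc(F)cc3)cc(-c3ccccc3O)n2)c1` is measured in a functional assay on HCT-15 cells (Homo sapiens) for inhibition; a higher number here means a weaker inhibitor, a lower number a stronger inhibitor. For compound 1 the assay reports only a limit, > 50000 nM. Compound 2 `Oc1cccc(-c2cc(-c3ccc(F)cc3)cc(-c3cccc(O)c3)n2)c1` carries the change 3-hydroxyphenyl in place of 2-hydroxyphenyl on an aromatic carbon relative to compound 1, and in this assay compound 2 gives 6310 nM. Among the measured compounds shown here, the step of an at least 7.9-fold lower number from compound 1 to compound 2 (0.89 log units; beyond the scatter) is the only measured instance of this change. Its size is bounded only from one side because of the limit of > 50000 nM in this assay, at which 2 of the 3 values shown sit.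

Compound 3 `Oc1ccccc1-c1cc(-c2ccc(OC(F)(F)F)cc2)cc(-c2ccccc2O)n1` differs from compound 1 in its core; that difference between the two cores is not broken down here. For compound 3 the assay again reports only a limit, > 50000 nM. Compound 4 `Oc1cccc(-c2cc(-c3ccc(OC(F)(F)F)cc3)cc(-c3ccccc3O)n2)c1` follows from compound 3 by 3-hydroxyphenyl in place of 2-hydroxyphenyl on an aromatic carbon. This is the same kind of change as that from compound 1 to compound 2, though the surroundings of the place are not identical: in the earlier pair the place is meta to a 3-hydroxyphenyl group and meta to a 4-fluorophenyl group, whereas here it is meta to a 2-hydroxyphenyl group and meta to a large group.

The expectation for compound 4 rests on the measured pair: the step from compound 3 to compound 4 is expected to be about an at least 3.3-fold lower number from compound 3 to compound 4 (0.52 log units; beyond the scatter), in line with the direction seen from compound 1 to compound 2 an at least 7.9-fold lower number from compound 1 to compound 2 (0.89 log units; beyond the scatter). Compound 4 is thus estimated to give roughly 15000 nM in this assay, with a plausible range from 4000 nM to 50000 nM.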

Compound 4, half-maximal inhibitory concentration: 9410 nM
Estimate against measurement, compound 4: 1.6-fold (0.20 log units) above, and the stated range covers the measured number.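

In this assay, 3-hydroxyphenyl in place of 2-hydroxyphenyl gives an at least 5.3-fold lower number from compound 3 to compound 4 (0.72 log units; beyond the scatter), so the direction seen with this change in the earlier pair recurs in a second setting. This shows that the direction carries across these two pairs, but it does not show that the size carries, and two pairs set no rule for the wider series: the same change on two cores in this assay, an at least 7.9-fold lower number (0.89 log units; beyond the scatter) from compound 1 to compound 2 and an at least 5.3-fold lower number (0.72 log units; beyond the scatter) from compound 3 to compound 4; the limit leaves it open whether they differ

The step with trifluoromethoxy in place of fluoro, an at least 5.3-fold lower number from compound 1 to compound 4 (0.72 log units; beyond the scatter), is likewise bounded from one side only, as is every step here that starts from a limit: the limit of > 50000 nM in this assay, at which 2 of the 4 values shown sit.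

On these data alone, the true size of each step remains open, as does any ranking of the two changes against each other. Also open, as far as these compounds go, is how the series responds when an amine or a carboxylic acid stands in place of the hydroxyl on either hydroxyphenyl group, or when a longer chain stands in place of the fluoro or trifluoromethoxy group.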